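The source may hold more compounds than are shown below. What is called first, only, known or untested is meant among the compounds shown, and "the series" means these compounds.

The compounds share one core and differ only in the group on an aromatic carbon of that core. Compound 1 `O=C(CCCCC1CCSS1)NCc1cn(CCCOc2ccc3cc(C(=O)O)c(=O)oc3c2)nn1` carries a carboxy group there, and in a functional assay on PC-12 cells (Rattus norvegicus) for cytotoxicity, read by MTT assay, with stated times of 3 h and 2 h, tested at 50 uM (on this read-out lower numbers stand for a weaker effect and higher numbers for a stronger effect at the one concentration tested), compound 1 gives 73.5%. Compound 2 `O=C(CCCCC1CCSS1)NCc1cn(CCCOc2ccc3cc(-c4ccccc4)c(=O)oc3c2)nn1` carries a phenyl instead, and in this assay compound 2 gives 23.1%. Compound 3 `O=C(CCCCC1CCSS1)NCc1cn(CCCOc2ccc3cc(-c4ccc(Br)cc4)c(=O)oc3c2)nn1` carries a 4-bromophenyl, and in this assay compound 3 gives 74.7%. Compound 3 holds the highest of the three numbers, though one of the two steps that end there, a number 1.2 percentage points higher from compound 1 to compound 3 (within the scatter), stays within the scatter, while the other, a number 51.6 percentage points higher from compound 2 to compound 3 (beyond the scatter), lies beyond it.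

Compound 4 `O=C(CCCCC1CCSS1)NCc1cn(CCCOc2ccc3cc(-c4ccc(Cl)cc4)c(=O)oc3c2)nn1` is not yet measured. It differs from compound 3 by chloro in place of bromo on an aromatic carbon. Among the measured compounds shown here, the only measured step that touches this position is a number 51.6 percentage points higher from compound 2 to compound 3 (beyond the scatter), where a halogen entered in place of hydrogen. Nothing measured tells how a chloro compares with a bromo at that spot. With one halogen swapped for another, the expected step in this assay is a number 6.7 percentage points lower from compound 3 to compound 4 (within the scatter), that is none beyond the scatter. Compound 4 is therefore estimated at 68%, with a range from 50% to 85%.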

Compound 4, a percentage reported as activity, at one concentration (the size of the read-out at that concentration, not a potency): 79.4%
Estimate against measurement, compound 4: 11.4 percentage points below; the range from low to high includes it.
By their numbers in this assay, from the lowest: compound 2; then compounds 1, 3 and 4 (each within the scatter of the next).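

In this assay the two halogens cannot be told apart at this spot on the ring, with a number 4.7 percentage points higher from compound 3 to compound 4 (within the scatter) as the step between them. Chloro in place of hydrogen gives a number 56.3 percentage points higher from compound 2 to compound 4 (beyond the scatter) as its step, so the large gap from the plain phenyl of compound 2 appears with two halogens and not with bromo alone. The 4-chlorophenyl group also stands level with the carboxy group, at a number 5.9 percentage points higher from compound 1 to compound 4 (within the scatter) for that swap, which leaves compound 2 as the only one of the four set apart.

On these data alone, whether a fluoro, a methoxy or an amine at this same place would match compound 4 or sit nearer compound 2 remains open. Nothing shown here explains why a halogen at this place separates these compounds from compound 2.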